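Swapping a Silyl Group for a Methoxyphenyl Group

This account rests on a few compounds, and the source may have more. Where it says the series, first, only, none or still open, it means among the compounds named here.

Compound 3 `C[Si](C)(C)c1cn(C[C@H](O)[C@H]2OC(=O)C(OCc3ccccc3)=C2OCc2ccccc2)nn1` stands at the higher end of the two numbers available in a functional assay on SW-620 cells (Homo sapiens) for antiproliferative activity, read by MTT assay, with a stated time of 72 h; a lower number here means a stronger inhibitor, a higher number a weaker inhibitor: compound 3 gives 56000 nM. Its nearest neighbour, compound 2 `CCCCCc1ccc(-c2cn(C[C@H](O)[C@H]3OC(=O)C(OCc4ccccc4)=C3OCc3ccccc3)nn2)cc1`, gives 12200 nM. Compound 1 `O=C1O[C@H]([C@@H](O)Cn2cc(-c3cccc(O)c3)nn2)C(OCc2ccccc2)=C1OCc1ccccc1` reaches only a limit in this assay and gives no number, > 100000 nM. Compound 4 `COc1ccc(-c2cn(C[C@H](O)[C@H]3OC(=O)C(OCc4ccccc4)=C3OCc3ccccc3)nn2)cc1` differs from compound 3 by a group of 8 heavy atoms (7 carbon, 1 oxygen; one six-membered aromatic ring of carbon only) in place of a group of 4 heavy atoms (3 carbon, 1 silicon; no ring), on an aromatic carbon. Among the compounds with values here, two measured steps bear on this change. The step of a 4.6-fold higher number from compound 2 to compound 3 (0.66 log units; beyond the scatter) shows that replacing a six-membered aromatic ring of carbon only with the silicon-bearing group raised the number, so the reverse move is expected to lower it. The step of an at least 8.1-fold lower number from compound 1 to compound 2 (0.91 log units; beyond the scatter) shows that which ring enters matters, with 3-hydroxyphenyl left at the limit, while the step of an at least 1.7-fold lower number from compound 1 to compound 3 (0.25 log units; that floor lies within the scatter) has a floor within the scatter. Because the step of a 4.6-fold higher number from compound 2 to compound 3 (0.66 log units; beyond the scatter) is only modest and the ring entering here is 4-methoxyphenyl rather than 4-pentylphenyl, only a modest drop is expected for compound 4, a 1.6-fold lower number from compound 3 to compound 4 (0.20 log units; within the scatter). Compound 4 is estimated at 35000 nM, in a range from 12000 nM to 110000 nM.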

Compound 4, half-maximal inhibitory concentration: 58200 nM
Estimate against measurement, compound 4: 1.7-fold (0.22 log units) below, within the range that was stated.
By their numbers in this assay, from the lowest: compound 2; then compounds 3 and 4 (each within the scatter of the next). At a limit, above all of these: compound 1.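

Placing 4-methoxyphenyl at this position in place of the silicon-bearing group gave a 1.0-fold higher number from compound 3 to compound 4 (0.02 log units; within the scatter) in this assay, so at this position an aromatic ring alone does not lower the number. Methoxy in place of pentyl gave a 4.8-fold higher number from compound 2 to compound 4 (0.68 log units; beyond the scatter), which shows that the group carried on the ring, not the ring itself, separates compound 2 from compound 3 and compound 4. Against 3-hydroxyphenyl there is only a floor, an at least 1.7-fold lower number from compound 1 to compound 4 (0.23 log units; that floor lies within the scatter), and compound 1 remains a limit of the assay: the limit of > 100000 nM in this assay, at which 1 of the 4 values shown sits.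

The compounds shown leave open whether the number keeps falling as the chain on the ring grows, since only methoxy and pentyl can be compared there. A propyl group or a longer chain such as octyl would bear on this, and an amine on the ring would show whether a chain is needed at all.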